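This account rests on a few compounds, and the source may have more. Where it says the series, first, only, none or still open, it means among the compounds named here.

Compound 2 `O=C(CCCc1ccc(F)cn1)N1CCc2c(Cl)c(O)c(O)c(Cl)c2C1` gives 25% in a functional assay (Homo sapiens), tested at 10 uM (on this read-out lower numbers stand for a stronger effect and higher numbers for a weaker effect at the one concentration tested), and compound 1 `O=C(CCCc1ccc(Cl)cc1)N1CCc2c(Cl)c(O)c(O)c(Cl)c2C1` gives 16%, the two lying within the scatter of each other, as the change a number 9 percentage points higher from compound 1 to compound 2 (within the scatter) shows. Compound 3 `O=C(CCCc1ccc([N+](=O)[O-])cn1)N1CCc2c(Cl)c(O)c(O)c(Cl)c2C1` differs from compound 2 by nitro in place of fluoro on an aromatic carbon. For the measured compounds named here, no measured step exchanges fluoro for nitro; the single step at hand only shows that a change of the aryl group of this chain left the read-out within the scatter. Compound 3 is therefore expected to give about 25%, between 8% and 45%, a step of no change at the digits printed from compound 2 to compound 3 (within the scatter) from compound 2, meaning no change beyond the scatter.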

Compound 3, a percentage reported as activity, at one concentration (the size of the read-out at that concentration, not a potency): 33%
For compound 3 the middle estimate is 8 percentage points below the measured one, within the range that was stated.
By their numbers in this assay, from the lowest: compounds 1, 2 and 3 (each within the scatter of the next, the first and the last beyond it).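

In this assay, nitro in place of fluoro on this aromatic carbon, para to a large group, stays within the scatter (a number 8 percentage points higher from compound 2 to compound 3 (within the scatter)), so three heavy atoms here in place of one leave the read-out without a clear change. For the compounds shown here, the 5-nitropyridin-2-yl group in place of 4-chlorophenyl gives the first step beyond the scatter, though a modest one (a number 17 percentage points higher from compound 1 to compound 3 (beyond the scatter)). No available evidence explains either step. On these data alone, it remains open how an amine or a carboxylic acid at this aromatic carbon would read out. As far as these compounds go, whether a longer chain to the aryl group would shift these numbers also remains open.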